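A few compounds are considered here, and "the series" means these few. Any claim that something is new, unique, unknown or untested is made for them only; others in the source may bear on it.

Measured compounds:
compound 1, `C=CCNC(=O)/C(C)=C(/C)c1ccc(Cl)cc1`, 180 mg/kg
compound 2, `C=CCNC(=O)/C(C)=C(/C)c1ccc(C)cc1`, 280 mg/kg
compound 3, `C/C(C(=O)NC1CC1)=C(/C)c1ccc(Cl)cc1`, 350 mg/kg

These three compounds were tested in a toxicity assay on the whole organism (strain Icem-CET (SPF Caw)) for cytotoxicity, with Mus musculus as the target; on this read-out lower numbers stand for an effect already at smaller amounts and higher numbers for an effect only at larger amounts of compound. Compound 1 and compound 2 share one core and differ only in a single change, (methyl in place of chloro on an aromatic carbon); in this assay the step was a 1.6-fold higher number from compound 1 to compound 2 (0.19 log units; within the scatter). Compound 3 carries a different core; the difference between the two cores is not broken down here, and its value in this assay lies within the scatter of both compound 1 and compound 2.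

Compound 4, `C/C(C(=O)NC1CC1)=C(/C)c1ccc(C)cc1`, is not yet measured. It differs from compound 3 by methyl in place of chloro on an aromatic carbon, the same change that was made from compound 1 to compound 2. On the core of compound 3 the step is expected to be a 1.4-fold higher number from compound 3 to compound 4 (0.15 log units; within the scatter), resting on the earlier step of a 1.6-fold higher number from compound 1 to compound 2 (0.19 log units; within the scatter). For compound 4 the estimate in this assay is therefore 500 mg/kg, with a likely range from 280 mg/kg to 900 mg/kg.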

Compound 4, dose for half-maximal effect: 110 mg/kg
Beside the measured number, compound 4's estimate is 4.5-fold (0.66 log units) above it, and the stated range ends above it.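

In this assay, methyl in place of chloro on an aromatic carbon gave a 3.2-fold lower number from compound 3 to compound 4 (0.50 log units; beyond the scatter), which does not match what the same change did on the core of compound 1. The two steps differ, so in this series the change does not carry over from one core to the other as a fixed step: the same change on two cores in this assay, a 1.6-fold higher number (0.19 log units; within the scatter) from compound 1 to compound 2 and a 3.2-fold lower number (0.50 log units; beyond the scatter) from compound 3 to compound 4, 4.9-fold (0.69 log units) apart, beyond the scatter of two such steps. Going by these compounds alone, with only one pair on each core, this shows that the outcome of the change differed between these two cores, but not what in the cores sets that difference or how the change would behave on any further core.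

The compounds shown carry only chloro or methyl on the aromatic ring, so it remains open how a methoxy group, a fluoro group or an amine would fare there. As far as these compounds go, it also remains open whether the two cores would again part ways with such a group.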